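A few compounds are considered here, and "the series" means these few. Any claim that something is new, unique, unknown or untested is made for them only; others in the source may bear on it.

Measured compounds in a functional assay on PC-3 cells (Homo sapiens) for cytotoxicity, read by sulforhodamine B assay, with a stated time of 48 h; on this read-out higher numbers stand for weaker inhibition of growth and lower numbers for stronger inhibition of growth:
compound 1 `Nc1nc(Cl)c2ncn(Cc3ccc(CCl)cc3)c2n1` — 7410 nM
compound 2 `ClCc1cccc(Cn2cnc3c(Cl)nc(Cl)nc32)c1` — 2390 nM
compound 3 `ClCc1ccc(Cn2cnc3c(Cl)nc(Cl)nc32)cc1` — 2690 nM

Compound 2 and compound 3 are built from the same atoms joined differently; the difference between the two cores is not broken down here, and their numbers in this assay lie within the scatter of one another, so no order between them is claimed. Compound 3 and compound 1 differ in one place, (amino in place of chloro on an aromatic carbon), and that single change brings a 2.8-fold higher number from compound 3 to compound 1 (0.44 log units; beyond the scatter), a modest but real step toward weaker growth inhibition.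

Compound 4 `Nc1nc(Cl)c2ncn(Cc3cccc(CCl)c3)c2n1` has not yet been measured. It stands to compound 2 exactly as compound 1 stands to compound 3: amino in place of chloro on an aromatic carbon, with the place described in the same words for both pairs, so the change is the same one. Because of a 2.8-fold higher number from compound 3 to compound 1 (0.44 log units; beyond the scatter) a step of similar size is expected here, a 2.8-fold higher number from compound 2 to compound 4 (0.45 log units; beyond the scatter), with the caveat that a single prior instance is a thin basis and the gap between the two pairs of cores is not itself resolved. Compound 4 is therefore estimated at 6700 nM in this assay, with a likely range from 3500 nM to 13000 nM.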

Compound 4, concentration for 50% growth inhibition: 9770 nM
Compound 4: the middle estimate sits 1.5-fold (0.16 log units) below what was measured; the range from low to high includes it.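

In this assay, amino in place of chloro on an aromatic carbon again moves the number toward weaker inhibition of growth, with a 4.1-fold higher number from compound 2 to compound 4 (0.61 log units; beyond the scatter) on a second core. For the compounds shown here, only two pairs carry this change, so the notes support a shared direction and a similar size on these two cores alone; they set no rule for other cores and give no reason for the step. The sizes on the two cores cannot be told apart: the same change on two cores in this assay, a 2.8-fold higher number (0.44 log units; beyond the scatter) from compound 3 to compound 1 and a 4.1-fold higher number (0.61 log units; beyond the scatter) from compound 2 to compound 4, 1.5-fold (0.17 log units) apart, within the scatter of two such steps

The compounds shown leave open whether this step belongs to amino alone, or whether a methylamino or methoxy group at the same place would bring a similar one. They also leave open whether the step would persist with a hydroxymethyl group in place of the chloromethyl group, and whether replacing the remaining chloro group on the shared core with a methyl group would alter it.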